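The compounds below may be only part of what the source reports. "The series", "measured", "known", "first", "only" and "open" are said of these compounds alone.

Compound 2, `COC(=O)C1=C(C(C)C)NC(=O)NC1c1cccc([N+](=O)[O-])c1`, is the weakest of the three measured compounds in an assay on HEK293 cells for antagonist activity at Voltage-dependent L-type calcium channel subunit alpha-1C (Oryctolagus cuniculus), read by FLIPR (a higher number here means a weaker inhibitor, a lower number a stronger inhibitor), where it reaches only the limit of the assay at > 100000 nM. Its methyl analogue, compound 1, `COC(=O)C1=C(C)NC(=O)NC1c1cccc([N+](=O)[O-])c1`, gives 11700 nM in this assay, and the step of an at least 8.5-fold higher number from compound 1 to compound 2 (0.93 log units; beyond the scatter) shows how much the larger group on the double-bonded ring carbon costs; compound 2 sits at the limit of > 100000 nM in this assay, at which 1 of the 3 values shown sits. Among the compounds with values here, compound 3, `CC1=C(C(=O)OC(C)C)C(c2cccc([N+](=O)[O-])c2)N(C(=O)C(C)C)C(=O)N1`, which carries an isopropyl ester, a methyl on the double-bonded carbon and an isobutyryl group on the ring nitrogen, gives 500 nM in this assay, a far lower number than compound 1, though it differs from compound 1 in more than one place, so no single step can be drawn between them.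

Compound 4, `COC(=O)C1=C(C(C)C)NC(=O)N(C(=O)OC(C)C)C1c1cccc([N+](=O)[O-])c1`, differs from compound 2 by isopropoxycarbonyl in place of hydrogen on an amide-type nitrogen in a ring. Within the data shown here, no measured step isolates a change on the ring nitrogen. Only the value of compound 3 hints that an acyl group on the ring nitrogen is compatible with strong inhibition, while the step from compound 1 to compound 2 warns that the isopropyl on the ring carbon, which compound 4 keeps, is costly. Compound 4 is therefore expected to improve on compound 2 by an at least 3.3-fold lower number from compound 2 to compound 4 (0.52 log units; beyond the scatter), but to remain a weak inhibitor, with an estimate of 30000 nM, between 5000 nM and 150000 nM.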

Compound 4, half-maximal inhibitory concentration: 10400 nM
Compound 4: middle estimate off by 2.9-fold (0.46 log units), on the high side; the measured number falls inside the stated range.
By their numbers in this assay, from the lowest: compound 3; then compounds 4 and 1 (each within the scatter of the next). At a limit, above all of these: compound 2.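

Within the data shown here, the step of an at least 9.6-fold lower number from compound 2 to compound 4 (0.98 log units; beyond the scatter) in this assay is the first measured change on the amide-type nitrogen in a ring, and it shows that isopropoxycarbonyl in place of hydrogen at this position brings a gain, not a loss. The value of compound 2 is a limit and not a number, so the step gives only a lower bound on that gain: the limit of > 100000 nM in this assay, at which 1 of the 4 values shown sits. The isopropyl group, three ring bonds from the ring atom that bears the 3-nitrophenyl group's neighbouring nitrogen substituent, stays in place through this change, and compound 4 still gives a measurable 10400 nM, so that group does not rule out inhibition once this nitrogen carries isopropoxycarbonyl.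

As far as these compounds go, whether isopropoxycarbonyl would bring a step of similar size on the core of compound 1, which has methyl in place of isopropyl, remains open. Also open, from the compounds shown here alone, is how other groups on this nitrogen would compare, such as a plain methyl, an acetyl, a longer alkoxycarbonyl chain or a chain ending in an amine.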